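From 3-cyanophenyl to 3-chloro-4-fluorophenyl on compound 3

The source may hold more compounds than are shown below. What is called first, only, known or untested is meant among the compounds shown, and "the series" means these compounds.

Measured so far in an in vitro ADME assay on microsomes from liver (Rattus norvegicus) for metabolic stability (a higher number here means faster removal of the compound, a lower number slower removal), for three compounds
compound 1 `CC(C)NC(=O)[C@H]1CC[C@@H](n2/c(=N/C(=O)c3ccc(F)cc3)[nH]c3ccc(CN4CCC[C@H]4C(C)(C)O)cc32)CC1` gives 455 mL.min-1.g-1
compound 2 `CC(C)NC(=O)[C@H]1CC[C@@H](n2/c(=N/C(=O)c3ccc(F)cc3)[nH]c3ccc(CN4CCCCC4)cc32)CC1` gives 451 mL.min-1.g-1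
compound 3 `CC(C)NC(=O)[C@H]1CC[C@@H](n2/c(=N/C(=O)c3cccc(C#N)c3)[nH]c3ccc(CN4CCC(C(C)(C)O)CC4)cc32)CC1` gives 17 mL.min-1.g-1

Compound 3 stands at 17 mL.min-1.g-1 as the lowest of the three numbers, beyond the scatter from both others. Compound 4 `CC(C)NC(=O)[C@H]1CC[C@@H](n2/c(=N/C(=O)c3ccc(F)c(Cl)c3)[nH]c3ccc(CN4CCC(C(C)(C)O)CC4)cc32)CC1` puts 3-chloro-4-fluorophenyl in place of 3-cyanophenyl on a carbonyl carbon, and 3-chloro-4-fluorophenyl in place of 3-cyanophenyl on a carbonyl carbon is the whole difference from compound 3. Going by the values given here, the only measured step of a 1.0-fold lower number from compound 1 to compound 2 (0.00 log units; within the scatter) lies within the scatter and sits elsewhere in the structure, so it gives no size for this change. Compound 1 at 455 mL.min-1.g-1 and compound 2 at 451 mL.min-1.g-1 carry fluorine and no nitrile in the group on the carbonyl carbon, but they also differ from compound 3 elsewhere, so their gap to it cannot be assigned to this group alone. A rise in this assay covering only part of that gap is therefore expected, and the estimated step is a 3.5-fold higher number from compound 3 to compound 4 (0.55 log units; beyond the scatter) towards a higher number. Compound 4 is estimated at 60 mL.min-1.g-1 with an expected range from 20 mL.min-1.g-1 to 200 mL.min-1.g-1 for its measurement.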

Compound 4, intrinsic clearance in microsomes: 44 mL.min-1.g-1
Beside the measured number, compound 4's estimate is 1.4-fold (0.13 log units) above it; low and high end bracket the measured number.
By their numbers in this assay, from the lowest: compound 3; then compound 4; then compounds 2 and 1 (each within the scatter of the next).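

In this assay, the group on a carbonyl carbon whose other neighbour is the amide-type nitrogen proves able to move the number on its own: 3-chloro-4-fluorophenyl in place of 3-cyanophenyl gives a 2.6-fold higher number from compound 3 to compound 4 (0.41 log units; beyond the scatter). This modest step is the first single-place change shown here to lie beyond the scatter, as the only earlier step sits elsewhere in the structure and lies within it. Nothing given here bears on why the number rises with this exchange.

The exchange removes the nitrile and brings in chlorine and fluorine together, so the data cannot divide the step among them. Going by these compounds, how a methoxy or trifluoromethyl group on the phenyl ring would compare at this place, with the rest of compound 3 unchanged, remains open.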